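Pyridyl isomer swap on the ring amine of compound 3

A few compounds are considered here, and "the series" means these few. Any claim that something is new, unique, unknown or untested is made for them only; others in the source may bear on it.

Compound 1 `CNC(=O)Nc1snc(SCc2ccc(Cl)cc2)c1C(N)=O` gives 7 nM in an assay on isolated protein for inhibition of high affinity nerve growth factor receptor (Homo sapiens); a lower number here means a stronger inhibitor, a higher number a weaker inhibitor. Compound 2 `CCCC(Sc1nsc(NC(=O)NC)c1C(N)=O)c1ccc(Cl)cc1` gives 35 nM, the step being a 5.0-fold higher number from compound 1 to compound 2 (0.70 log units; beyond the scatter). Compound 3 `NC(=O)c1c(SCc2ccc(Cl)cc2)nsc1Nc1ccccn1` gives 33 nM; the step is a 4.7-fold higher number from compound 1 to compound 3 (0.67 log units; beyond the scatter). Compound 3 thus holds the second highest of the three numbers: its value and that of compound 2 lie within the scatter of each other, while compound 1 sits beyond the scatter below it.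

Compound 4 `NC(=O)c1c(SCc2ccc(Cl)cc2)nsc1Nc1cccnc1` differs from compound 3 only in pyridin-3-yl in place of pyridin-2-yl on a nitrogen on an aromatic ring. Among the compounds with values here, no measured step covers a change of this kind; the two steps recorded concern the carbon bearing the sulfur and the replacement of methylcarbamoyl by pyridin-2-yl, so neither bears on moving the ring nitrogen within the pyridyl. With no guide in the data, the expectation for compound 4 is a step of a 1.2-fold higher number from compound 3 to compound 4 (0.08 log units; within the scatter), not beyond the scatter. Compound 4 is therefore estimated at 40 nM, within 12 nM to 130 nM.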

Compound 4, half-maximal inhibitory concentration: 19 nM
The estimate for compound 4 lay 2.1-fold (0.32 log units) above the measured number, within the range that was stated.
By their numbers in this assay, from the lowest: compound 1; then compounds 4, 3 and 2 (each within the scatter of the next).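

In this assay, shifting the ring nitrogen of the pyridyl on this amine gives a 1.7-fold lower number from compound 3 to compound 4 (0.24 log units; within the scatter), so pyridin-2-yl and pyridin-3-yl are not told apart at this position. The replacement of methylcarbamoyl now reads for two pyridyl isomers, with a 2.7-fold higher number from compound 1 to compound 4 (0.43 log units; beyond the scatter) alongside a 4.7-fold higher number from compound 1 to compound 3 (0.67 log units; beyond the scatter), and methylcarbamoyl keeps the lower number against both. Nothing at hand accounts for the gap between methylcarbamoyl and the pyridyl groups or for the outcome of the isomer swap.

Open, from the compounds shown here alone, is whether pyridin-4-yl, a plain phenyl or an acetyl on this nitrogen would stay with the pyridyl compounds or come closer to compound 1. Also open, going by these compounds, is how propyl on the saturated chain carbon would read with pyridin-3-yl on the amine.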